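The compounds below may be only part of what the source reports. "The series", "measured", "known", "first", "only" and "open" are said of these compounds alone.

The measured compounds:
compound 1, `COc1ccc(-c2cc3ccccc3nc2/C=C/C(=O)c2c(OC)cccc2OC)cc1`, 4470 nM
compound 2, `COc1ccc(-c2cc3ccccc3nc2/C=C/C(=O)c2ccc(N)cc2)cc1`, 9290 nM
compound 3, `COc1ccc(-c2cc3ccccc3nc2/C=C/C(=O)c2ccco2)cc1`, 6240 nM

All three were tested in a functional assay on H184B5F5/M10 cells (Homo sapiens) for antiproliferative activity, read by XTT assay, with a stated time of 72 h; on this read-out higher numbers stand for weaker inhibition and lower numbers for stronger inhibition. They share one core and differ only in the group attached to the carbonyl carbon. On the bare numbers compound 3 falls in the middle of the three, but neither neighbour stands clearly apart from it: the step of a 1.4-fold higher number from compound 1 to compound 3 (0.14 log units; within the scatter) and the step of a 1.5-fold lower number from compound 2 to compound 3 (0.17 log units; within the scatter) both lie within the usual scatter of repeated measurements. Among the measured compounds shown here, only the step of a 2.1-fold higher number from compound 1 to compound 2 (0.32 log units; beyond the scatter) reaches beyond that scatter, and even this one is modest.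

Compound 4, `COc1ccc(-c2cc3ccccc3nc2/C=C/C(=O)c2ccccn2)cc1`, has not yet been measured. It differs from compound 3 at the same place that varies among the three measured compounds: pyridin-2-yl in place of furan-2-yl on a carbonyl carbon. All three measured steps concern swaps of the group on this carbonyl carbon, and all were small; two of them could not be told apart from chance variation. For the measured compounds named here, a fourth ring at this place is therefore expected to behave much the same, with no step in this assay beyond the scatter in either direction. The expected step is a 1.0-fold lower number from compound 3 to compound 4 (0.02 log units; within the scatter). For compound 4 the estimate in this assay is 6000 nM, with a range from 3000 nM to 12000 nM.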

Compound 4, half-maximal inhibitory concentration: 4140 nM
The estimate for compound 4 lay 1.4-fold (0.16 log units) above the measured number, and the stated range covers the measured number.
By their numbers in this assay, from the lowest: compounds 4, 1, 3 and 2 (each within the scatter of the next, the first and the last beyond it).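

In this assay, the six-membered pyridin-2-yl takes the place of the five-membered furan-2-yl with a 1.5-fold lower number from compound 3 to compound 4 (0.18 log units; within the scatter), so neither the ring size nor the swap of ring oxygen for ring nitrogen separates this pair on the carbonyl carbon. The new ring also cannot be told apart from the 2,6-dimethoxyphenyl group, with a 1.1-fold lower number from compound 1 to compound 4 (0.03 log units; within the scatter), which extends the range of aromatic rings tolerated here to a nitrogen-containing one. The 4-aminophenyl compound now lies beyond the scatter from a second compound, with a 2.2-fold lower number from compound 2 to compound 4 (0.35 log units; beyond the scatter), but this step is still modest and compound 3 goes against any clean split, since it stays within the scatter of compound 2 as well as of compounds 1 and 4.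

Nothing available here explains why these different rings give such similar numbers. As far as these compounds go, it remains open whether this tolerance extends beyond aromatic rings, for example to a short alkyl chain or a piperidine ring on the carbonyl carbon, or to a phenyl ring carrying a carboxylic acid.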